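A Halogen Swap on an Amide-Bound Aryl Ring

A few compounds are considered here, and "the series" means these few. Any claim that something is new, unique, unknown or untested is made for them only; others in the source may bear on it.

Compound 2 `Cc1ccc(N2C(=O)C/C(=C\c3cccc(C(=O)Nc4cccc(F)c4)c3)C2=O)cc1` carries a 3-fluorophenyl group on its amide nitrogen. In an ADME assay on HCT-116 cells (Homo sapiens) for cytotoxicity, read by MTT assay, with a stated time of 72 h (a lower number here means a stronger inhibitor, a higher number a weaker inhibitor), compound 2 gives only a limit of the assay, > 100000 nM, and no number. Two related compounds share this outcome. Compound 1 `Cc1ccc(NC(=O)c2cccc(/C=C3\CC(=O)N(c4ccccc4)C3=O)c2)cc1` reaches only the limit > 100000 nM in this assay. Compound 3 `COc1ccc(NC(=O)c2cccc(/C=C3\CC(=O)N(c4ccccc4)C3=O)c2)cc1` likewise stops at the limit > 100000 nM in this assay. Among the compounds with values here, because of the limit of > 100000 nM in this assay, at which 3 of the 3 values shown sit, every value so far sits at the same boundary, so compound 2 cannot be ranked against its neighbours.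

The next compound, compound 4 `Cc1ccc(N2C(=O)C/C(=C\c3cccc(C(=O)Nc4ccc(Cl)cc4)c3)C2=O)cc1`, differs from compound 2 in one place: 4-chlorophenyl in place of 3-fluorophenyl on an amide-type nitrogen. Within the data shown here, only one measured step exists, and it concerns a different ring: a step that the two limits leave unreadable from compound 1 to compound 3, which the two limits leave unreadable. No measured step therefore touches the amide-bound ring changed here, and nothing shown points to a direction in this assay; the likeliest picture is that the step from compound 2 to compound 4 stays within the scatter, with compound 4 again reaching only a limit. The expected step is a number no higher from compound 2 to compound 4 (the limit leaves the size open), none beyond the scatter. Compound 4 is thus estimated at 100000 nM in this assay, within 40000 nM to 300000 nM.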

Compound 4, half-maximal inhibitory concentration: > 100000 nM
Compound 4: only a limit was reported; the forecaster's own chance of this, stated with the estimate: 85%; the middle value lies on the limit itself.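

No step can be read from compound 2 to compound 4, because each gives only a limit of the assay and no number: the limit of > 100000 nM in this assay, at which 4 of the 4 values shown sit.

The compounds shown leave open how compound 2 and compound 4 truly rank in this assay, and whether any change to the aryl group on the amide nitrogen can shift the result.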